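The compounds below may be only part of what the source reports. "The series", "measured", "known", "first", "only" and "open" are said of these compounds alone.

Measured so far:
compound 1, `COc1cc(C(C)=O)ccc1OCCCN1CCC(C(c2ccccc2)c2ccccc2)CC1`: 6.31 nM
compound 2, `COc1cc(C(=O)O)ccc1OCCCN1CCC(C(c2ccc(F)cc2)c2ccc(F)cc2)CC1`: 79.4 nM

In a functional assay (aorta) with Oryctolagus cuniculus as the target (on this read-out lower numbers stand for tighter binding and higher numbers for weaker binding), compound 1 gives 6.31 nM, while compound 2 gives 79.4 nM, the higher of the two numbers and beyond the scatter from compound 1. Compound 3, `Nc1ccc(OCCCN2CCC(C(c3ccc(F)cc3)c3ccc(F)cc3)CC2)cc1`, has not yet been measured; it differs from compound 2 by 4-aminophenyl in place of 4-carboxy-2-methoxyphenyl on an oxygen on a saturated carbon. Among the measured compounds shown here, no step between measured compounds covers that change. Given that compound 2 stands at 79.4 nM, a moderate step to a lower number is expected in this assay, a 4.0-fold lower number from compound 2 to compound 3 (0.60 log units; beyond the scatter), so compound 3 is estimated at 20 nM, between 4 nM and 100 nM.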

Compound 3, dissociation constant: 31.6 nM
For compound 3 the middle estimate is 1.6-fold (0.20 log units) below the measured one, within the range that was stated.
By their numbers in this assay, from the lowest: compound 1; then compound 3; then compound 2.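

In this assay, the change gives a 2.5-fold lower number from compound 2 to compound 3 (0.40 log units; beyond the scatter), so on this oxygen the carboxylic acid is not needed to reach the lower number, and the methoxy can go with it. Because the carboxylic acid, the methoxy and the amine all change in this one step, the step cannot be assigned to any one of them. Nothing available bears on why the number moves.

Going by these compounds, it remains open how a 4-amino-2-methoxyphenyl group would read, which would separate the amine from the methoxy. A plain phenyl group on the same oxygen would likewise show what the amine itself contributes.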